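Aminophenyl in Place of Methoxyphenyl: Expected Cytotoxicity

A few compounds are considered here, and "the series" means these few. Any claim that something is new, unique, unknown or untested is made for them only; others in the source may bear on it.

Three compounds have been measured in an ADME assay on J774 cells (Mus musculus, strain BALB/c) for cytotoxicity, read by resazurin assay, with a stated time of 72 h; on this read-out lower numbers stand for higher toxicity in this test and higher numbers for lower toxicity in this test:

compound 1, `CC(/C=N/N(C)c1ccc([N+](=O)[O-])cc1)=N\NC(=O)c1ccccc1O`, gives 31500 nM
compound 2, `CC(/C=N/N(C)c1ccc([N+](=O)[O-])cc1)=N\NC(=O)c1cc([N+](=O)[O-])cc([N+](=O)[O-])c1`, gives 39000 nM
compound 3, `COc1ccc(C(=O)N/N=C(C)/C=N/Nc2ccc([N+](=O)[O-])cc2)cc1`, gives > 100000 nM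

For compound 3 the value > 100000 nM is a limit of this assay, not a number; that is where compound 3 stands, as shown by the limit of > 100000 nM in this assay, at which 1 of the 3 values shown sits. Compound 1 and compound 2 each give a number on this read-out, and their two values show no separation beyond the usual scatter of such measurements.

The untested compound 4, `CC(/C=N/Nc1ccc([N+](=O)[O-])cc1)=N\NC(=O)c1ccccc1N`, differs from compound 3 in one place: 2-aminophenyl in place of 4-methoxyphenyl on a carbonyl carbon. Nothing measured here isolates this change, so the size of the step in this assay can only be guessed. Compound 1, which carries a 2-hydroxyphenyl group at the same carbonyl carbon, gives 31500 nM, a number rather than a limit, which leaves open that compound 4 may also fall inside the measurable range.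

Compound 4 is expected to give 60000 nM in this assay, within a range from 25000 nM to 120000 nM. This estimate means a step of an at least 1.6-fold lower number from compound 3 to compound 4 (0.22 log units; that floor lies within the scatter), with the real chance that only a limit is reported again.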

Compound 4, half-maximal cytotoxic concentration: 29800 nM
Estimate against measurement, compound 4: 2.0-fold (0.30 log units) above, and the stated range covers the measured number.
By their numbers in this assay, from the lowest: compounds 4, 1 and 2 (each within the scatter of the next). At a limit, above all of these: compound 3.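

Putting 2-aminophenyl in place of 4-methoxyphenyl on a carbonyl carbon gives, in this assay, an at least 3.3-fold lower number from compound 3 to compound 4 (0.52 log units; beyond the scatter), so this change brings the compound from the limit into the measurable range, and on this read-out a lower number stands for higher toxicity in this test. For the compounds shown here, this is the first comparison of compounds that differ in only one place, which shows that the group on this carbonyl carbon can by itself shift the result beyond the usual scatter. Only a minimum can be given for the step, and the real size remains unknown because compound 3 stands at a limit: the limit of > 100000 nM in this assay, at which 1 of the 4 values shown sits.

On these data alone, whether the lower number goes with the added amine or simply with the loss of the methoxy group stays open, and a plain phenyl group on the same carbonyl carbon would help to separate the two. Compound 1 and compound 4 differ in more than one place, so their closely similar values do not show whether a hydroxyl group and an amine have the same effect at this carbonyl carbon.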